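This account rests on a few compounds, and the source may have more. Where it says the series, first, only, none or still open, it means among the compounds named here.

Compound 1 `CN(Cc1cccc(F)c1)C(=O)CCCNC(=O)c1ccc(S(C)(=O)=O)c([N+](=O)[O-])c1` — in an assay on isolated protein for inhibition of thyroid hormone receptor alpha (Homo sapiens), read by fluorescence polarization (on this read-out lower numbers stand for stronger inhibition and higher numbers for weaker inhibition), compound 1 gives > 60000 nM, which is a limit of the assay rather than a number.
Compound 2 `CC1CCN(C(=O)CCNC(=O)c2ccc(S(C)(=O)=O)c([N+](=O)[O-])c2)CC1` — in this assay compound 2 gives > 60000 nM, again a limit.
Compound 3 `CS(=O)(=O)c1ccc(C(=O)NCCCC(=O)N2Cc3ccccc3C2)cc1[N+](=O)[O-]` — in this assay compound 3 gives > 60000 nM, again a limit.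

All three measured compounds share one core and differ only in the amide group at the end of the chain. None of them reaches a measurable value: every result sits at the limit of > 60000 nM in this assay, at which 3 of the 3 values shown sit, so compound 3 cannot be placed above or below compound 1 or compound 2. Among the measured compounds shown here, the one step that joins two measured compounds in a single change, a step that the two limits leave unreadable from compound 1 to compound 3, therefore teaches nothing about size or direction.

Compound 4 `CS(=O)(=O)c1ccc(C(=O)NCCCC(=O)N2CCCCC2)cc1[N+](=O)[O-]` carries the next change in the same place: a group of 6 heavy atoms (5 carbon, 1 nitrogen; one six-membered non-aromatic ring with 1 hetero atom) in place of a group of 9 heavy atoms (8 carbon, 1 nitrogen; one five-membered non-aromatic ring with 1 hetero atom, one six-membered aromatic ring of carbon only), on a carbonyl carbon. For the measured compounds named here, no measured step shows what such a change does in this assay, and the only evidence is that three different amide groups on this core all stayed at the limit. The step from compound 3 to compound 4, a step that the limit leaves unreadable from compound 3 to compound 4, is therefore expected to be unreadable as well. Compound 4 is estimated at 80000 nM, with a range from 30000 nM to 300000 nM, most likely reported again as a limit in this assay.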

Compound 4, half-maximal inhibitory concentration: > 60000 nM
Compound 4: only a limit was reported (the forecaster's own chance of this, stated with the estimate: 85%); the middle value does not contradict the limit.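

In this assay compound 4 gives > 60000 nM, which is again a limit and not a number. Its steps from compound 1, compound 2 and compound 3 therefore cannot be read, in either size or direction: the limit of > 60000 nM in this assay, at which 4 of the 4 values shown sit. The compounds shown leave open which amide group, if any, would give a measurable value on the shared core.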